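Cyclohexyl in Place of Hexyl on the Ring Nitrogen

A few compounds are considered here, and "the series" means these few. Any claim that something is new, unique, unknown or untested is made for them only; others in the source may bear on it.

Compound 1, `CC(C)n1nc(-c2ccccc2)c(-c2ccccc2)cc1=O`, gives 152000 nM in an assay on microsomes from liver for inhibition of sterol O-acyltransferase 1 (Rattus norvegicus); on this read-out lower numbers stand for stronger inhibition and higher numbers for weaker inhibition.
Compound 2, `CCCCCCn1nc(-c2ccccc2)c(-c2ccccc2)cc1=O`, gives 57000 nM in this assay.
Compound 3, `CCCCCCCCCn1nc(-c2ccccc2)c(-c2ccccc2)cc1=O`, gives 85000 nM in this assay.

These three compounds share one core and differ only in the group carried on the aromatic nitrogen. Compound 2 has the lowest number of the three: it sits a 2.7-fold lower number from compound 1 to compound 2 (0.43 log units; beyond the scatter), a step beyond the scatter, while compound 3 stands a 1.5-fold higher number from compound 2 to compound 3 (0.17 log units; within the scatter), which is within the scatter. The step of a 1.8-fold lower number from compound 1 to compound 3 (0.25 log units; within the scatter) is also within the scatter.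

Compound 4, `O=c1cc(-c2ccccc2)c(-c2ccccc2)nn1C1CCCCC1`, has not yet been measured. It differs from compound 2 in one place: cyclohexyl in place of hexyl on an aromatic nitrogen. Among the compounds with values here, no measured step swaps a chain for a ring, so the bearing of the known steps is indirect. They show that changing the size of the group on this nitrogen moved the numbers only modestly, and that the shortest, branched group gave the highest number. A step in this assay that stays near the scatter is therefore expected, perhaps a little upward.

Compound 4 is estimated to give 80000 nM, in a range from 30000 nM to 220000 nM. This estimate means the step of a 1.4-fold higher number from compound 2 to compound 4 (0.15 log units; within the scatter) is expected.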

Compound 4, half-maximal inhibitory concentration: > 300000 nM
Compound 4 was reported as a limit; the forecaster's own chance of this, stated with the estimate: 10%; at least 3.7-fold (0.57 log units) between middle value and limit.
By their numbers in this assay, from the lowest: compounds 2, 3 and 1 (each within the scatter of the next, the first and the last beyond it). At a limit, above all of these: compound 4.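

The value for compound 4 is a limit and not a number: the limit of > 300000 nM in this assay, at which 1 of the 4 values shown sits.

Hexyl and cyclohexyl both hold 6 carbon atoms, yet closing the chain into a ring brings an at least 5.2-fold higher number from compound 2 to compound 4 (0.72 log units; beyond the scatter), and replacing nonyl with the same ring brings an at least 3.5-fold higher number from compound 3 to compound 4 (0.54 log units; beyond the scatter), so this position responds to more than the number of carbons on the nitrogen, which the chain and isopropyl compounds alone could not show. Against isopropyl the change gives an at least 1.9-fold higher number from compound 1 to compound 4 (0.29 log units; that floor lies within the scatter), so no order can be read between these two groups.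

From the compounds shown here alone, how far the number for compound 4 lies past its limit stays unknown. The compounds shown also leave open whether a smaller ring such as cyclopentyl, or a hexyl chain ending in an amine, would keep the numbers of the chains.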